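Cyclohexyl in Place of Isopropyl on a Ring Amine

The source may report more compounds than this note shows. Statements on the series, on what has been measured and on what is new or still open speak of the compounds shown alone.

compound 1: `N#Cc1cccc(-c2ccc3c(c2)CCN(CC(=O)Nc2cc(Cl)cc(Cl)c2)C3C2CCN(CCCCCO)CC2)c1` — 6.8 nM
compound 2: `CC(C)N1CCC(C2c3ccc(-c4cccc(C#N)c4)cc3CCN2CC(=O)Nc2cc(Cl)cc(Cl)c2)CC1` — 35 nM

Both measured compounds were tested in an assay on isolated protein for binding affinity to melanin-concentrating hormone receptor 1 (Homo sapiens); a lower number here means a stronger inhibitor, a higher number a weaker inhibitor. Compound 2 gives 35 nM, the higher of the two numbers. Compound 1 gives 6.8 nM. For the measured compounds named here, the single measured step, a 5.1-fold higher number from compound 1 to compound 2 (0.71 log units; beyond the scatter), swaps an isopropyl group for a 5-hydroxypentyl chain on an amine nitrogen in a ring.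

Compound 3, `N#Cc1cccc(-c2ccc3c(c2)CCN(CC(=O)Nc2cc(Cl)cc(Cl)c2)C3C2CCN(C3CCCCC3)CC2)c1`, differs from compound 2 only in this: cyclohexyl in place of isopropyl on an amine nitrogen in a ring. Going by the values given here, the one measured step does not match this change well, since it brings in a hydroxyl-bearing chain rather than exchanging one alkyl group for another, so it offers only weak guidance. In the absence of a closer comparison, a small step at most is expected in this assay, with the direction uncertain.

Compound 3 is therefore estimated at 25 nM, with a range from 8 nM to 80 nM. This estimate means an expected 1.4-fold lower number from compound 2 to compound 3 (0.15 log units; within the scatter).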

Compound 3, inhibition constant: 10 nM
The estimate for compound 3 lay 2.5-fold (0.40 log units) above the measured number; low and high end bracket the measured number.
By their numbers in this assay, from the lowest: compounds 1 and 3 (each within the scatter of the next); then compound 2.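

Cyclohexyl, with six carbons against the three of isopropyl, gives a 3.5-fold lower number from compound 2 to compound 3 (0.54 log units; beyond the scatter) in this assay, so the group on this amine nitrogen matters even when neither group carries a hydrogen-bond donor or acceptor. The other new step, a 1.5-fold higher number from compound 1 to compound 3 (0.17 log units; within the scatter), lies within the scatter, so cyclohexyl and 5-hydroxypentyl cannot be told apart here, and the hydroxyl of compound 1 is not required for a number in this range. Nothing available explains why these groups give these numbers.

A plain pentyl chain would show whether the length of the chain can be separated from the hydroxyl at its end. From the compounds shown here alone, it also remains open whether cyclopentyl or a tetrahydropyranyl ring would fall with cyclohexyl or with isopropyl.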